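The compounds below may be only part of what the source reports. "The series", "measured", "known", "first", "only" and "open" are said of these compounds alone.

Measured compounds:
- Compound 1 `CCOc1nc2cccc(C(=O)NCCCOC)c2n1Cc1ccc(-c2ccccc2-c2nnn[nH]2)cc1` gives 27.9% in an assay on isolated protein for inhibition of NEDD8-activating enzyme E1 regulatory subunit (Homo sapiens), read by Western blot, with stated times of 10 min and 30 min, tested at 25 uM; on this read-out higher numbers stand for more inhibition at the one concentration tested (going by the name of the read-out) and lower numbers for less inhibition.
- Compound 2 `CCOc1nc2cccc(C(=O)Nc3ccc(F)cc3)c2n1Cc1ccc(-c2ccccc2-c2nnn[nH]2)cc1` gives 45.3% in this assay.
- Compound 3 `CCOc1nc2cccc(C(=O)Nc3ccncc3)c2n1Cc1ccc(-c2ccccc2-c2nnn[nH]2)cc1` gives 39.8% in this assay.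

Compound 3 stands second highest of the three; the gap a number 5.5 percentage points lower from compound 2 to compound 3 (within the scatter) lies within the scatter, whereas the step of a number 11.9 percentage points higher from compound 1 to compound 3 (beyond the scatter) lies beyond it. Compound 4 `CCOc1nc2cccc(C(=O)NCc3ccccc3)c2n1Cc1ccc(-c2ccccc2-c2nnn[nH]2)cc1` differs from compound 3 in one place: benzyl in place of pyridin-4-yl on an amide-type nitrogen. The steps of a number 17.4 percentage points higher from compound 1 to compound 2 (beyond the scatter) and a number 11.9 percentage points higher from compound 1 to compound 3 (beyond the scatter) show the 4-fluorophenyl and pyridin-4-yl amides above the 3-methoxypropyl amide, while the step of a number 5.5 percentage points lower from compound 2 to compound 3 (within the scatter) is small. Among the measured compounds shown here, no measured step tells of a benzyl amide, so the expected step of a number 2.8 percentage points lower from compound 3 to compound 4 (within the scatter) is small and may stay within the scatter. Compound 4 is therefore estimated at 37%, with a range from 22% to 52%.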

Compound 4, a percentage reported as inhibition, at one concentration (the size of the read-out at that concentration, not a potency): 48.9%
Compound 4: middle estimate off by 11.9 percentage points, on the low side; the range from low to high includes it.
By their numbers in this assay, from the lowest: compound 1; then compounds 3, 2 and 4 (each within the scatter of the next).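

With benzyl on the amide-type nitrogen, the phenyl ring stands on a saturated chain carbon bound to that nitrogen, and a number 21 percentage points higher from compound 1 to compound 4 (beyond the scatter) in this assay shows that the ring need not sit directly on the nitrogen for the value to lie beyond that of the 3-methoxypropyl amide. The steps of a number 9.1 percentage points higher from compound 3 to compound 4 (within the scatter) and a number 3.6 percentage points higher from compound 2 to compound 4 (within the scatter) do not separate benzyl from pyridin-4-yl or 4-fluorophenyl. Nothing available gives a reason for these steps. As far as these compounds go, it remains open how a phenethyl amide, or a benzyl group carrying an amine or a carboxylic acid, would read here.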